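A few compounds are considered here, and "the series" means these few. Any claim that something is new, unique, unknown or untested is made for them only; others in the source may bear on it.

Compound 1 `CC1(C)[C@H]2CC[C@]1(C)N(Cc1cn(-c3ccccc3)nn1)C(=O)C2` gives 160 nM
Compound 2 `Cc1ccccc1-n1cc(CN2C(=O)C[C@@H]3CC[C@@]2(C)C3(C)C)nn1` gives 250 nM
Compound 3 `CC1(C)[C@H]2CC[C@]1(C)N(Cc1cn(-c3ccc(Cl)cc3)nn1)C(=O)C2` is not yet measured

In a functional assay on PANC-1 cells (Homo sapiens) for inhibition, read by MTT assay, with a stated time of 24 h (a lower number here means a stronger inhibitor, a higher number a weaker inhibitor), compound 2 stands at 250 nM and within the scatter of compound 1. The change to compound 3 is 4-chlorophenyl in place of 2-methylphenyl on an aromatic nitrogen with 4-chlorophenyl in place of 2-methylphenyl on an aromatic nitrogen. For the measured compounds named here, the one measured step bearing on it is a 1.6-fold higher number from compound 1 to compound 2 (0.19 log units; within the scatter) for methyl in place of hydrogen on an aromatic carbon, and no measured step covers chlorine. No step beyond the scatter is therefore expected in this assay here. The estimate means a 1.3-fold lower number from compound 2 to compound 3 (0.10 log units; within the scatter) as the expected step. Compound 3 is estimated at 200 nM with 70 nM to 550 nM as its expected range.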

Compound 3, half-maximal inhibitory concentration: 440 nM
Beside the measured number, compound 3's estimate is 2.2-fold (0.34 log units) below it, within the range that was stated.
By their numbers in this assay, from the lowest: compounds 1, 2 and 3 (each within the scatter of the next, the first and the last beyond it).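

In this assay, for the compounds shown here, 4-chlorophenyl on the aromatic nitrogen gives the first step beyond the scatter, a 2.8-fold higher number from compound 1 to compound 3 (0.44 log units; beyond the scatter) with a chloro group as the only change. Set against the 2-methylphenyl group, the same compound stays within the scatter, with a 1.8-fold higher number from compound 2 to compound 3 (0.25 log units; within the scatter), so these two substituted phenyl groups are not separated here. No available evidence bears on the origin of either step.

Open, as far as these compounds go, is whether an amine, a methoxy group or a carboxylic acid in place of the chloro would follow compound 3. From the compounds shown here alone, a pyridyl or benzyl group on the aromatic nitrogen also remains open.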